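Swapping trifluoromethoxy for benzyl on the aryl ring

The compounds below may be only part of what the source reports. "The series", "measured", "known", "first", "only" and "open" are said of these compounds alone.

Compound 1, `COc1ccccc1N1CCN(CCCNc2ncccc2C(=O)C2CC2)CC1`, gives 2 nM in a functional assay on aorta for antagonist activity at Alpha-1D adrenergic receptor (Rattus norvegicus); on this read-out higher numbers stand for weaker binding and lower numbers for tighter binding.
Compound 2, `COc1ccccc1N1CCN(CCCNc2ccncc2C(=O)N(C)C)CC1`, gives 50.1 nM in this assay.
Compound 3, `CN(C)C(=O)c1cccnc1NCCCN1CCN(c2ccccc2OC(F)(F)F)CC1`, gives 100 nM in this assay.

Compound 3 has the highest number of the three; compound 2 sits within the scatter of it, while compound 1 lies far lower. The unmeasured compound 4, `CN(C)C(=O)c1cccnc1NCCCN1CCN(c2ccccc2Cc2ccccc2)CC1`, differs from compound 3 in one place: benzyl in place of trifluoromethoxy on an aromatic carbon. Among the measured compounds shown here, no measured pair shows this exact change, so there is no step to lean on, and the shared core of compound 3 is kept. The expectation is therefore cautious: the step of a 1.5-fold higher number from compound 3 to compound 4 (0.18 log units; within the scatter) in this assay is expected to stay within the scatter, or at most to be a modest rise. Compound 4 is thus expected to give 150 nM in this assay, with a range from 40 nM to 600 nM.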

Compound 4, dissociation constant: 79.4 nM
Estimate against measurement, compound 4: 1.9-fold (0.28 log units) above; measured number inside the range.
By their numbers in this assay, from the lowest: compound 1; then compounds 2, 4 and 3 (each within the scatter of the next).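

Benzyl brings a six-membered aromatic ring of carbon only where trifluoromethoxy has no ring, yet in this assay the swap gives a 1.3-fold lower number from compound 3 to compound 4 (0.10 log units; within the scatter). Among the compounds shown here, this is the first pair differing in one place, and it shows that this aromatic carbon takes either group without a clear change in the number. Nothing measured here explains why.

On these data alone, it remains open whether a fluorine atom, a hydroxyl group or an amine in this place would also leave the number unchanged.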